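The source may hold more compounds than are shown below. What is called first, only, known or untested is meant among the compounds shown, and "the series" means these compounds.

In an ADME assay on MT4 cells (Homo sapiens) for cytotoxicity (a lower number here means that less compound is tolerated, a higher number that more compound is tolerated), compound 3 (`CCNC(=S)Nc1cccc(C(F)(F)F)c1`) reads > 100000 nM as a limit and not a number. Compound 3 alone stands at the limit of > 100000 nM in this assay, at which 1 of the 3 values shown sits, and so offers no exact starting point.

The move to compound 4 (`FC(F)(F)c1cccc(NC(=S)Nc2cccc(Br)c2)c1`) puts 3-bromophenyl in place of ethyl on an amide-type nitrogen, a change counted as 3-bromophenyl in place of ethyl on an amide-type nitrogen at that single place.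

For the measured compounds named here, two measured steps bear on it. Compound 2 (`FC(F)(F)c1cccc(NC(=S)Nc2ccc(I)cc2)c1`), with 4-iodophenyl on that nitrogen, gives 10000 nM in this assay, and an at least 10-fold higher number from compound 2 to compound 3 (1.00 log units; beyond the scatter) is the closest exchange on record, run in the opposite direction. Putting a substituted phenyl back on the nitrogen should therefore bring the number down again. Compound 1 (`CC[C@H]1CC[C@H](c2ccc(NC(=S)Nc3cccc(C(F)(F)F)c3)cc2)CC1`) gives 39000 nM in this assay with 4-ethylcyclohexyl where compound 2 has iodo, and a 3.9-fold lower number from compound 1 to compound 2 (0.59 log units; beyond the scatter) is the smaller of the two steps. The group on the aromatic ring is therefore expected to matter less than the exchange on the nitrogen.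

The expected size and direction, a lower number and beyond the scatter, is an at least 8.3-fold lower number from compound 3 to compound 4 (0.92 log units; beyond the scatter) in this estimate. For compound 4 the estimated value is 12000 nM and the expected range runs from 4000 nM to 35000 nM in this assay as well.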

Compound 4, half-maximal cytotoxic concentration: 9200 nM
Beside the measured number, compound 4's estimate is 1.3-fold (0.12 log units) above it; the range from low to high includes it.
By their numbers in this assay, from the lowest: compounds 4 and 2 (each within the scatter of the next); then compound 1. At a limit, above all of these: compound 3.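

In this assay, 3-bromophenyl in place of ethyl on the amide-type nitrogen gives an at least 10-fold lower number from compound 3 to compound 4 (1.03 log units; beyond the scatter), so the fall in tolerated concentration is no longer tied to 4-iodophenyl alone, and a second halogen-bearing phenyl group on that nitrogen reads far from the ethyl compound. Exchanging one such group for the other gives a 1.1-fold lower number from compound 2 to compound 4 (0.04 log units; within the scatter), so this change, which alters both the halogen and its place on the ring, does not separate the two compounds in this assay. Compound 3 is a limit and not a number, so the step from it is a bound and not an exact size: the limit of > 100000 nM in this assay, at which 1 of the 4 values shown sits.

The compounds shown leave open how a phenyl group carrying an amine or a carboxylic acid, or a longer chain such as butyl in place of ethyl, would read on that nitrogen in this assay. They also leave open whether bromo and iodo would read alike at one fixed place on the ring, as compound 2 and compound 4 differ in both the halogen and its place.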